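Cytotoxicity of pyridazinone amides: replacing the halogenated aryl

This account rests on a few compounds, and the source may have more. Where it says the series, first, only, none or still open, it means among the compounds named here.

Compound 1 `CNC(=O)c1cc(Oc2ccc(NC(=O)c3nn(-c4ccc(C)cc4)c(=O)cc3C)cc2F)ccn1`: 10600 nM
Compound 2 `Cc1cc(=O)n(-c2ccc(Br)cc2F)nc1C(=O)Nc1ccc(Oc2ncnc3ccsc23)cc1`: 10600 nM
Compound 3 `Cc1cc(=O)n(-c2ccc(Br)cc2F)nc1C(=O)Nc1ccc(Oc2ncnc3sccc23)cc1`: 6300 nM

In a functional assay on HepG2 cells (Homo sapiens) for cytotoxicity, read by MTT assay, with a stated time of 72 h (a lower number here means a stronger inhibitor, a higher number a weaker inhibitor), compound 3 gives 6300 nM, the lowest of the three numbers, though compound 1 and compound 2 both lie within the scatter of it. Going by the values given here, the one single-point step seen, a 1.7-fold lower number from compound 2 to compound 3 (0.23 log units; within the scatter), concerns the ether-linked bicycle, not the aryl on the ring nitrogen. Compound 4 `Cc1cc(=O)n(-c2ccc(F)c(F)c2)nc1C(=O)Nc1ccc(Oc2ncnc3sccc23)cc1` differs from compound 3 by 3,4-difluorophenyl in place of 4-bromo-2-fluorophenyl on an aromatic nitrogen. Among the compounds with values here, no measured step touches this position, so nothing in the data predicts a shift beyond the scatter. Compound 4 is therefore expected to come out close to compound 3, as a 1.1-fold higher number from compound 3 to compound 4 (0.05 log units; within the scatter). The estimate for compound 4 is 7000 nM, with a range from 2500 nM to 20000 nM.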

Compound 4, half-maximal inhibitory concentration: 16800 nM
The estimate for compound 4 lay 2.4-fold (0.38 log units) below the measured number, within the range that was stated.
By their numbers in this assay, from the lowest: compounds 3, 1, 2 and 4 (each within the scatter of the next, the first and the last beyond it).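

In this assay, going by these compounds alone, the aryl on the aromatic nitrogen does register: 3,4-difluorophenyl in place of 4-bromo-2-fluorophenyl gives a 2.7-fold higher number from compound 3 to compound 4 (0.43 log units; beyond the scatter), a modest change but the only step here beyond the scatter. The earlier compounds shown here offered no step at this position, and compound 3 and compound 4 now stand as the two ends of the set. Nothing measured here accounts for the shift. The compounds shown do not separate the loss of the bromine from the moved fluorine, since both change in this one step. Going by these compounds, how an aryl carrying an amine or a carboxylic acid would read at this position remains open.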